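The compounds below may be only part of what the source reports. "The series", "measured", "known", "first", "only" and "open" are said of these compounds alone.

Working notes on the series. In a functional assay on HEK293 cells for agonist activity at D(4) dopamine receptor (Homo sapiens), read by FLIPR (on this read-out higher numbers stand for larger maximal responses and lower numbers for smaller maximal responses), compound 1 `CCc1cccc(NC(=O)CN2CCC(c3cccc[n+]3[O-])CC2)c1` gives 62%. Compound 2 `Cc1cccc(C(=O)NCN2CCC(c3ccccn3)CC2)c1` gives 67% in this assay. For the measured compounds named here, the two numbers lie within the usual scatter of each other, so compound 1 cannot be set apart from compound 2 on this read-out; the pair shows only that the two values are close.

Compound 3 `O=C(CN1CCC(c2cccc[n+]2[O-])CC1)Nc1cc(Cl)cc(Cl)c1` has not yet been measured in this assay. It differs from compound 1 in one place: 3,5-dichlorophenyl in place of 3-ethylphenyl on an amide-type nitrogen. Going by the values given here, no pair of measured compounds shares this change, so no step size can be read from the data. With the two measured values close to each other and nothing in the series moving beyond the scatter, the step expected from compound 1 to compound 3 in this assay is a number 2 percentage points lower from compound 1 to compound 3 (within the scatter), small and in no settled direction. Compound 3 is estimated at 60%, with a range from 40% to 80%.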

Compound 3, largest response reached (reported as efficacy), in percent of the reference or control that the assay uses: 68%
Compound 3: the middle estimate sits 8 percentage points below what was measured; low and high end bracket the measured number.
By their numbers in this assay, from the lowest: compounds 1, 2 and 3 (each within the scatter of the next).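

On an amide-type nitrogen whose other neighbours are the carbonyl carbon, the series now has its first readable step in this assay: 3,5-dichlorophenyl in place of 3-ethylphenyl gives a number 6 percentage points higher from compound 1 to compound 3 (within the scatter). Both groups are one six-membered aromatic ring of carbon only with the same heavy-atom count, so exchanging ethyl for two chlorines on that ring is a change this read-out does not separate from repeated-measurement scatter. No independent measurement on the compounds shown bears on the reason for this result.

The compounds shown leave open whether the maximal response would stay this close with a methoxy group, an amine or a carboxylic acid on the phenyl ring. They also leave open how a saturated ring such as cyclohexyl would fare in place of the aromatic ring on this nitrogen.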